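Cytotoxicity notes: halogen swap on the fused indole-type core

The source may report more compounds than this note shows. Statements on the series, on what has been measured and on what is new or still open speak of the compounds shown alone.

Measured so far in an ADME assay on HeLa cells (Homo sapiens) for cytotoxicity, read by ATP content, with a stated time of 3 days; on this read-out higher numbers stand for lower toxicity in this test and lower numbers for higher toxicity in this test:
compound 1, `CS(=O)(=O)CCCn1c(Cn2c(=O)n(C3CC3)c3ccncc32)cc2cc(Cl)ccc21`: > 50000 nM
compound 2, `CS(=O)(=O)CCCn1c(Cn2c(=O)n(C3CC3)c3ccncc32)cc2ccccc21`: > 100000 nM

Compound 2 `CS(=O)(=O)CCCn1c(Cn2c(=O)n(C3CC3)c3ccncc32)cc2ccccc21` stands at a limit of this assay, not at a number. In this assay compound 2 gives > 100000 nM, which is a limit. Compound 1 `CS(=O)(=O)CCCn1c(Cn2c(=O)n(C3CC3)c3ccncc32)cc2cc(Cl)ccc21` likewise gives only a limit in this assay, > 50000 nM. Among the compounds with values here, the one measured step, a step that the two limits leave unreadable from compound 1 to compound 2, is therefore the limit of > 100000 nM in this assay, at which 1 of the 2 values shown sits, set against the limit of > 50000 nM in this assay, at which 1 of the 2 values shown sits, and carries no readable size.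

Compound 3 `CS(=O)(=O)CCCn1c(Cn2c(=O)n(C3CC3)c3ccncc32)cc2cc(Br)ccc21` differs from compound 2 by bromo in place of hydrogen on an aromatic carbon. Within the data shown here, the only step that bears on it is the unreadable one from compound 1 to compound 2, so no size beyond the scatter can be expected from it in either direction, and a further limit is the likeliest outcome. The step from compound 2 to compound 3 is estimated as an at least 1.2-fold lower number from compound 2 to compound 3 (0.09 log units; that floor lies within the scatter). Compound 3 is expected at 80000 nM, within 30000 nM to 200000 nM.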

Compound 3, half-maximal cytotoxic concentration: > 50000 nM
Compound 3: only a limit was reported; the forecaster's own chance of this, stated with the estimate: 70%; the middle value lies beyond the limit too.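

In this assay, within the data shown here, compound 1, compound 2 and compound 3 all give only limits, and no step among them can be read. The compounds shown leave open whether hydrogen, chloro or bromo on that aromatic carbon separates them at all in this read-out.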